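The compounds below may be only part of what the source reports. "The series", "measured", "known", "first", "only" and "open" are said of these compounds alone.

Measured so far in an ADME assay on microsomes from liver (Rattus norvegicus) for metabolic stability; on this read-out higher numbers stand for a longer-lived compound and lower numbers for a shorter-lived compound:
compound 1 `CC(C)C(CC1C(=O)NC(=O)N1C)c1ccc(-c2ccc3cccc(F)c3c2)[nH]c1=O`: < 0.0667 h
compound 2 `CCC(/C=C1\OC(=O)NC1=O)(CC)c1ccc(-c2ccc3cccc(C(F)(F)F)c3c2)[nH]c1=O`: 1.09 h

Compound 1 has no exact half-life, and its value is a limit of the assay rather than a number. It stands at the limit of < 0.0667 h in this assay, at which 1 of the 2 values shown sits. Going by the values given here, compound 2 gives the only true number, 1.09 h.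

Compound 3 `CC(C)C(/C=C1/C(=O)NC(=O)N1C)c1ccc(-c2ccc3cccc(F)c3c2)[nH]c1=O` keeps the core of compound 1 and exchanges one group, on a saturated chain carbon bound to an aromatic carbon and a saturated chain carbon: a group of 9 heavy atoms (5 carbon, 2 nitrogen, 2 oxygen; one five-membered non-aromatic ring with 2 hetero atoms) in place of a group of 9 heavy atoms (5 carbon, 2 nitrogen, 2 oxygen; one five-membered non-aromatic ring with 2 hetero atoms), on a saturated chain carbon bound to an aromatic carbon and a saturated chain carbon. Among the compounds with values here, no measured step shows what this exchange does in this assay, so any forecast is loose. A modest upward move is expected, and the estimated change is an at least 2.9-fold higher number from compound 1 to compound 3 (0.47 log units; beyond the scatter). The result may still be reported only as a limit. For compound 3 the expected half-life is 0.2 h, with an estimated range of 0.07 h to 0.8 h.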

Compound 3, half-life: 1.08 h
The estimate for compound 3 lay 5.4-fold (0.73 log units) below the measured number, outside the stated range (above it).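

In this assay, the new group brings an at least 16-fold higher number from compound 1 to compound 3 (1.20 log units; beyond the scatter), a large step beyond the usual scatter. That size is only a minimum, since compound 1 is held at a limit of the assay rather than a number: the limit of < 0.0667 h in this assay, at which 1 of the 3 values shown sits. The step also shows that the half-life is sensitive to this place, on a saturated chain carbon bound to an aromatic carbon and a saturated chain carbon, as both groups have 9 heavy atoms of the same kinds, equal counts of hydrogen-bond donors and acceptors, and no net charge, while the count of double bonds outside aromatic rings goes from 2 to 3.

Whether that added double bond alone accounts for the step remains open. So does how a carboxylic acid or an amine at this place would fare.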